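Cytotoxicity notes on the shared core: compound 4

The source may hold more compounds than are shown below. What is called first, only, known or untested is meant among the compounds shown, and "the series" means these compounds.

Compound 1 `COC(=O)c1ccc(NCc2cncn2Cc2ccc(-c3ccccc3)cc2)cc1-c1ccccc1`: > 1000 nM
Compound 2 `COC(=O)c1ccc(NCc2cncn2Cc2ccc(-c3ccccc3)cc2)cc1`: > 10000 nM
Compound 3 `COC(=O)c1ccc(NCc2cncn2Cc2cccc(Cl)c2)cc1-c1ccccc1`: > 10000 nM

In a toxicity assay on NIH3T3 cells (Mus musculus) for cytotoxicity, read by resazurin assay (a higher number here means that more compound is needed for the effect, a lower number that less compound is needed), compound 1 gives > 1000 nM, which is a limit of the assay and not a number. Compound 2 gives > 10000 nM, also a limit. Compound 3 likewise gives > 10000 nM, a limit. Compound 1 thus sits at the limit of > 1000 nM in this assay, at which 1 of the 3 values shown sits. Compound 2 and compound 3 sit at the limit of > 10000 nM in this assay, at which 2 of the 3 values shown sit. The measured steps are a step that the two limits leave unreadable from compound 1 to compound 2 and a step that the two limits leave unreadable from compound 1 to compound 3, so neither carries a readable size, and neither touches the methoxycarbonyl group.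

Compound 4 `COc1ccc(NCc2cncn2Cc2ccc(-c3ccccc3)cc2)cc1-c1ccccc1` differs from compound 1 by methoxy in place of methoxycarbonyl on an aromatic carbon. Going by the values given here, no measured step bears on this change, and all three values shown are limits, so no step size can be taken over. The expectation is therefore no change beyond the scatter, with a high chance that only a limit is reported again. Compound 4 is estimated at 20000 nM, between 3000 nM and 100000 nM. The step that the limit leaves unreadable from compound 1 to compound 4 is accordingly expected to be small.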

Compound 4, half-maximal effective concentration: > 1000 nM
Compound 4 was reported as a limit; the forecaster's own chance of this, stated with the estimate: 85%; the middle value is on the limit's open side.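

Compound 1 and compound 4 are both reported only as limits in this assay, so the step between them cannot be read. The compounds shown leave open whether methoxy in place of methoxycarbonyl changes the cytotoxicity at all, and how far either compound lies from its limit.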